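Trimming a pentyl chain to isopropyl

The compounds below may be only part of what the source reports. "The series", "measured", "known", "first", "only" and "open" are said of these compounds alone.

In a functional assay on HT-29 cells (Homo sapiens) for inhibition, read by luminescence and CellTiter-Glo, with a stated time of 24 h (on this read-out lower numbers stand for an effect already at smaller amounts and higher numbers for an effect only at larger amounts of compound), compound 1 `CCn1nc(C(=O)N[C@H]2COc3ccccc3N(C)C2=S)nc1Cc1ccccc1` gives 17 nM, compound 2 `CCCn1nc(C(=O)N[C@H]2COc3ccccc3N(C)C2=S)nc1Cc1ccccc1` gives 288 nM and compound 3 `CCCCCn1nc(C(=O)N[C@H]2COc3ccccc3N(C)C2=S)nc1Cc1ccccc1` gives 805 nM, the highest number of the three. Compound 4 `CC(C)n1nc(C(=O)N[C@H]2COc3ccccc3N(C)C2=S)nc1Cc1ccccc1` has not yet been measured. It differs from compound 3 in one place, with isopropyl in place of pentyl on an aromatic nitrogen of a five-membered aromatic ring: isopropyl in place of pentyl on an aromatic nitrogen.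

Three measured steps change the chain on that same nitrogen: a 17-fold higher number from compound 1 to compound 2 (1.23 log units; beyond the scatter), then a 47-fold higher number from compound 1 to compound 3 (1.68 log units; beyond the scatter), and a 2.8-fold higher number from compound 2 to compound 3 (0.45 log units; beyond the scatter). The first two are large and the third is modest, yet all lie beyond the scatter. Across these three compounds, a longer chain goes with a higher number, and no compound goes against this. Isopropyl is shorter than pentyl, so a move back towards lower numbers is expected in this assay. Going by the values given here, no measured compound carries isopropyl, however, so the size of that move is uncertain. The expected step is a 6.7-fold lower number from compound 3 to compound 4 (0.83 log units; beyond the scatter), larger than the modest step and smaller than the largest one. For compound 4 the estimated value is 120 nM, with an expected range from 30 nM to 450 nM.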

Compound 4, half-maximal effective concentration: 360 nM
Beside the measured number, compound 4's estimate is 3.0-fold (0.48 log units) below it; low and high end bracket the measured number.
By their numbers in this assay, from the lowest: compound 1; then compounds 2 and 4 (each within the scatter of the next); then compound 3.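

In this assay, swapping the straight propyl chain for branched isopropyl makes no readable difference: a 1.3-fold higher number from compound 2 to compound 4 (0.10 log units; within the scatter) is a step that stays inside the usual scatter of repeated measurements. Trimming pentyl to isopropyl gives only a 2.2-fold lower number from compound 3 to compound 4 (0.35 log units; beyond the scatter) in this series, while adding a methyl to the ethyl group on the carbon bound to the aromatic nitrogen gives a 21-fold higher number from compound 1 to compound 4 (1.33 log units; beyond the scatter) in the opposite direction. At this position, then, the large jump separates ethyl from both propyl and isopropyl, whether the added carbon sits at the end of the chain or on the carbon bound to the nitrogen, and the further lengthening to pentyl adds much less.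

No measurement shown here explains why ethyl stands apart from these groups. As far as these compounds go, whether a methyl group on the same nitrogen, a cyclopropyl ring or a chain ending in an amine would sit with ethyl or with propyl and isopropyl remains open.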